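Swapping the Amide Group on Compound 2 for Isopropyl

This account rests on a few compounds, and the source may have more. Where it says the series, first, only, none or still open, it means among the compounds named here.

Values so far in a physicochemical assay for solubility, at pH 7; on this read-out lower numbers stand for lower solubility and higher numbers for higher solubility
- Compound 1 `CN1CCN(c2ccc(C(=O)Nc3n[nH]c4cc(C(=O)Nc5ccccc5)sc34)cc2)CC1` gives 6000 nM
- Compound 2 `CN1CCN(c2ccc(C(=O)Nc3n[nH]c4cc(C(=O)NC5CCc6ccccc65)sc34)cc2)CC1` gives < 1000 nM as a limit, not a number

Compound 2 therefore stands only at a limit, with no exact number to start from. The next compound, compound 3 `CC(C)NC(=O)c1cc2[nH]nc(NC(=O)c3ccc(N4CCN(C)CC4)cc3)c2s1`, has not yet been measured. It carries isopropyl in place of 2,3-dihydro-1H-inden-1-yl on an amide-type nitrogen and the rest of the structure stays the same.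

Within the data shown here, one measured step bears on this change, an at least 6.0-fold lower number from compound 1 to compound 2 (0.77 log units; beyond the scatter) when that same group replaced phenyl on an amide-type nitrogen. Isopropyl itself has no measured value on this core. Going by compound 1 at 6000 nM a move back toward higher numbers in this assay is expected, of a size similar to that step. The estimated step is an at least 4.0-fold higher number from compound 2 to compound 3 (0.60 log units; beyond the scatter) and it remains rough. Compound 3 is expected at 4000 nM within an estimated range from 1200 nM to 15000 nM.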

Compound 3, solubility: 59000 nM
Estimate against measurement, compound 3: 15-fold (1.17 log units) below; the measured number lies above the stated range.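

In this assay, isopropyl on the amide-type nitrogen brings an at least 59-fold higher number from compound 2 to compound 3 (1.77 log units; beyond the scatter), and it also brings a 9.8-fold higher number from compound 1 to compound 3 (0.99 log units; beyond the scatter). This position can therefore move the read-out strongly in both directions, and the group without a ring carries the number past that of compound 1 instead of merely returning to it. Compound 2 stands at a limit and not at an exact number, so the first of these steps has only a lower bound: the limit of < 1000 nM in this assay, at which 1 of the 3 values shown sits.

Three groups cannot separate the effect of having no ring from that of carbon count, so what sets these numbers stays unresolved. Cyclopropyl, tert-butyl, a longer chain such as n-butyl, or a chain ending in an amine would show how far the pattern extends.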